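The compounds below may be only part of what the source reports. "The series", "measured", "known", "first", "only" and "open" are said of these compounds alone.

Measured so far in a toxicity assay on HeLa cells (Homo sapiens) for cytotoxicity; a lower number here means that less compound is tolerated, a higher number that more compound is tolerated:

Compound 1 `COc1nc(C2CCOCC2)ccc1[C@@H](c1ccccc1)[C@@](O)(CCN(C)C)c1cccc2ccccc12`: compound 1 gives 22.5 ug/mL.
Compound 2 `COc1nc(-c2ccc(C#N)cc2)ccc1[C@@H](c1ccccc1)[C@@](O)(CCN(C)C)c1cccc2ccccc12`: compound 2 reaches a limit of the assay, > 64 ug/mL.
Compound 3 `COc1ncc(-c2ccccc2)cc1[C@@H](c1ccccc1)[C@@](O)(CCN(C)C)c1ccccc1`: compound 3 gives 11.9 ug/mL.

Compound 2 thus stands at the top of the measured values, where (the limit of > 64 ug/mL in this assay, at which 1 of the 3 values shown sits). Compound 4 `COc1nc(-c2ccc(Cl)cc2)ccc1[C@@H](c1ccccc1)[C@@](O)(CCN(C)C)c1cccc2ccccc12` differs from compound 2 by chloro in place of cyano on an aromatic carbon. Among the compounds with values here, the one measured step, an at least 2.8-fold higher number from compound 1 to compound 2 (0.45 log units; beyond the scatter), concerns a different group and does not bear on the exchange of chloro for cyano; no measured step does. With compound 2 already at the limit, compound 4 is expected to remain in the same region, at an estimated 50 ug/mL, with a range from 20 ug/mL to 100 ug/mL. The step that this estimate means, an at least 1.2-fold lower number from compound 2 to compound 4 (0.10 log units; that floor lies within the scatter), is expected to stay within the scatter, and the assay may well report only a limit again.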

Compound 4, half-maximal cytotoxic concentration: > 64 ug/mL
Compound 4 was reported as a limit; the forecaster's own chance of this, stated with the estimate: 40%; middle value at least 1.2-fold (0.10 log units) from the limit.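

In this assay compound 4 gives > 64 ug/mL, again a limit of the assay. With 4-chlorophenyl in place of oxan-4-yl, the result is an at least 2.8-fold higher number from compound 1 to compound 4 (0.45 log units; beyond the scatter), so among these compounds the higher number does not depend on the nitrile of compound 2. The exchange of chloro for cyano itself cannot be read, because both values are limits: the limit of > 64 ug/mL in this assay, at which 2 of the 4 values shown sit.

The compounds shown leave open whether an unsubstituted phenyl at this position on the core of compound 1 would already give such a limit. They also leave open whether an amine or a carboxylic acid in place of the chloro would bring the number back to a measurable value.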